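The source may report more compounds than this note shows. Statements on the series, on what has been measured and on what is new or still open speak of the compounds shown alone.

Compound 2 `Cc1cc(CN(CC2CC2)C(CC(=O)O)c2ccc(Cl)cc2)ccc1OCCN1C(=O)CCC1=O` gives 65 nM in an assay on CHO cells for displacement of a labelled ligand from C-X-C chemokine receptor type 3 (Homo sapiens), with a stated time of 60 min (a lower number here means a stronger inhibitor, a higher number a weaker inhibitor), the second highest of the three numbers measured. Its nearest neighbour is compound 3 `Cc1cc(CN(CC2CC2)[C@@H](CC(=O)O)c2ccc(Cl)cc2)ccc1OCCN1C(=O)CCC1=O`, which in this assay gives 42 nM; the difference, a 1.5-fold lower number from compound 2 to compound 3 (0.19 log units; within the scatter), lies within the scatter, and at the place where they differ (the fact that one of compounds 2 and 3 is drawn with a defined configuration and the other without, at the place where they differ). Compound 1 `CCCN(Cc1ccc(OCCN2C(=O)CCC2=O)c(OC)c1)C(C(=O)O)c1ccc(Cl)cc1` gives 256 nM, the highest number of the set. Compound 4 `Cc1cc(CN(CCC(F)(F)F)C(CC(=O)O)c2ccc(Cl)cc2)ccc1OCCN1C(=O)CCC1=O` is compound 2 with 2,2,2-trifluoroethyl in place of cyclopropyl on a saturated chain carbon bound to an amine nitrogen. No measured step touches a saturated chain carbon bound to an amine nitrogen: the one step measured, a 1.5-fold lower number from compound 2 to compound 3 (0.19 log units; within the scatter), concerns only a stereocentre, so there is no shown basis to expect a shift beyond the scatter in either direction. Compound 4 is therefore estimated at 90 nM, between 30 nM and 270 nM, which is expected to mean a 1.4-fold higher number from compound 2 to compound 4 (0.14 log units; within the scatter).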

Compound 4, half-maximal inhibitory concentration: 650 nM
The estimate for compound 4 lay 7.2-fold (0.86 log units) below the measured number; the measured number lies above the stated range.
By their numbers in this assay, from the lowest: compounds 3 and 2 (each within the scatter of the next); then compound 1; then compound 4.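

In this assay, 2,2,2-trifluoroethyl in place of cyclopropyl gives a 10-fold higher number from compound 2 to compound 4 (1.00 log units; beyond the scatter), which shows that the group at this place can move the number well beyond the scatter. For the compounds shown here, the only earlier step between compounds differing in one place, a 1.5-fold lower number from compound 2 to compound 3 (0.19 log units; within the scatter), concerned a stereocentre and could not show this. Nothing given here explains the size of this step.

The step removes a ring and brings in fluorine together, leaving the two unseparated. A plain butyl chain at this place, with neither ring nor fluorine, would tell them apart.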